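The compounds below may be only part of what the source reports. "The series", "measured", "known", "first", "only" and "open" are said of these compounds alone.

The measured compounds:

Compound 1, `C=CCCCCOc1ccccc1-c1cnc(OCCCC=C)n1C`, gives 7000 nM.
Compound 2, `C=CCCCCCOc1ncc(-c2ccccc2OCCCCC=C)n1C`, gives 63000 nM.
Compound 3, `C=CCCOc1ncc(-c2ccccc2OC)n1C`, gives 27000 nM.

These three compounds were tested in a functional assay on MCF7 cells (Homo sapiens) for inhibition, read by colorimetric assay and MTT assay, with a stated time of 72 h; on this read-out lower numbers stand for stronger inhibition and higher numbers for weaker inhibition. Compound 1 gives the lowest number of the three. Compound 2 differs from compound 1 in one place: but-3-en-1-yl in place of vinyl on a saturated chain carbon, three bonds along the chain from an oxygen on an aromatic ring. This change made the step of a 9.0-fold higher number from compound 1 to compound 2 (0.95 log units; beyond the scatter), so the longer chain went with weaker inhibition here. Compound 3 stands between the other two: against compound 2 it shows a smaller number, against compound 1 a larger one, and both gaps lie beyond the scatter. The difference between the core of compound 3 and the core of compound 1 is not broken down here.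

Compound 4, `C=CCCCCOc1ncc(-c2ccccc2OC)n1C`, has not yet been measured in this assay. It differs from compound 3 in one place: but-3-en-1-yl in place of vinyl on a saturated chain carbon, two bonds along the chain from an oxygen on an aromatic ring. This is the same kind of change as that from compound 1 to compound 2, but not the same one: in compound 3 the carbon that carries the change sits two bonds along the chain from the aromatic oxygen, whereas in compound 1 it sits three bonds along. Among the measured compounds shown here, because the only comparable step, a 9.0-fold higher number from compound 1 to compound 2 (0.95 log units; beyond the scatter), went toward a higher number, compound 4 is expected to give a higher number than compound 3, with the step estimated at a 3.0-fold higher number from compound 3 to compound 4 (0.47 log units; beyond the scatter). The estimate for compound 4 is 80000 nM, with a range from 25000 nM to 250000 nM.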

Compound 4, half-maximal inhibitory concentration: 5000 nM
Estimate against measurement, compound 4: 16-fold (1.20 log units) above; measured number outside the range, below it.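

In this assay, but-3-en-1-yl in place of vinyl on a saturated chain carbon, two bonds along the chain from an oxygen on an aromatic ring, produced a 5.4-fold lower number from compound 3 to compound 4 (0.73 log units; beyond the scatter) and thus went with stronger inhibition, the opposite of what the earlier step on the other core showed. Set side by side, the two steps run in opposite directions, and the gap separating them lies beyond what the scatter of two such steps would give: the same change on two cores in this assay, a 9.0-fold higher number (0.95 log units; beyond the scatter) from compound 1 to compound 2 and a 5.4-fold lower number (0.73 log units; beyond the scatter) from compound 3 to compound 4, 49-fold (1.69 log units) apart, beyond the scatter of two such steps. This shows that the direction of the change did not carry from the core of compound 1 to the core of compound 3, so a step read on one of these cores is no guide to the other; it does not show why, since the two pairs differ both in the core and in where the changed carbon sits, two bonds along the chain in one pair and three in the other, and two steps cannot separate these.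

The compounds shown leave open how inhibition runs with a longer chain than hex-5-en-1-yl on the core of compound 3. Also open, from the compounds shown here alone, is what a fully saturated chain, or a chain ending in an amine or a carboxylic acid, would do on either core.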